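The compounds below may be only part of what the source reports. "The series", "measured", "known", "first", "only" and "open" are said of these compounds alone.

Compound 1: `CC(C)c1nc(C(=O)NC[C@@H]2[C@H]3CN(C4CCC4)C[C@@H]23)c2ccccn12`; in a functional assay on CHO cells for agonist activity at 5-hydroxytryptamine receptor 4 (Homo sapiens), read by a luciferase reporter and cAMP accumulation, with a stated time of 4 h (a lower number here means that less compound is needed, a higher number that more compound is needed for the effect), compound 1 gives 18 nM.
Compound 2: `COC(=O)N1CCC(N2C[C@@H]3[C@@H](CNC(=O)c4nc(C(C)C)n5ccccc45)[C@@H]3C2)CC1`; in this assay compound 2 gives 9.7 nM.

The two numbers differ only by a 1.9-fold lower number from compound 1 to compound 2 (0.27 log units; within the scatter), so compound 2 cannot be told apart from compound 1 on these measurements. Compound 3, `CC(C)c1nc(C(=O)NC[C@@H]2[C@H]3CN(CC(C)(C)CO)C[C@@H]23)c2ccccn12`, is changed at the same ring nitrogen: 2-(hydroxymethyl)-2-methylpropyl in place of 1-(methoxycarbonyl)piperidin-4-yl on an amine nitrogen in a ring. Among the compounds with values here, the one measured step bears on it only loosely, since it exchanged a different pair of groups at that place, and it stayed within the scatter. A step of about that size, a 1.5-fold higher number from compound 2 to compound 3 (0.19 log units; within the scatter), is therefore expected, with no shift beyond the scatter. Compound 3 is estimated at 15 nM, between 5 nM and 45 nM.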

Compound 3, half-maximal effective concentration: 5.7 nM
Compound 3: middle estimate off by 2.6-fold (0.42 log units), on the high side; measured number inside the range.
By their numbers in this assay, from the lowest: compounds 3, 2 and 1 (each within the scatter of the next, the first and the last beyond it).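

At this ring nitrogen, a ring is not required for activity in this assay: the open chain 2-(hydroxymethyl)-2-methylpropyl matches 1-(methoxycarbonyl)piperidin-4-yl, with a 1.7-fold lower number from compound 2 to compound 3 (0.23 log units; within the scatter). Set against cyclobutyl, the same chain gives a 3.2-fold lower number from compound 1 to compound 3 (0.50 log units; beyond the scatter), the first modest step at this place that clears the scatter. Nothing measured here explains that step. On these data alone, whether the hydroxymethyl part of the chain matters stays open. So does how a longer chain, or one ending in a carboxylic acid or an amine, would compare.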